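Shifting the fluorine on the pendant phenyl of compound 1

The compounds below may be only part of what the source reports. "The series", "measured", "known", "first", "only" and "open" are said of these compounds alone.

Compound 1 `Cc1cccc(NC(=O)CN2CCC(c3cccc(F)c3)CC2)c1` is an amide-linked piperidine bearing a 3-fluorophenyl group. In a functional assay on HEK293 cells for agonist activity at D(4) dopamine receptor (Homo sapiens), read by FLIPR (a lower number here means that less compound is needed, a higher number that more compound is needed for the effect), compound 1 gives 512 nM. Within the data shown here, the only other measured compound, compound 2 `CC(C)Oc1cccc(NC(=O)CN2CCC(c3cccc[n+]3[O-])CC2)c1`, carries a different aryl group on the piperidine and a different substituent on the anilide; in this assay compound 2 gives 555 nM. Compound 1 therefore shows the lower of the two numbers, but the gap to compound 2 lies within the scatter, so the two are not distinguished by these data.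

Compound 3 `Cc1cccc(NC(=O)CN2CCC(c3ccccc3F)CC2)c1` has not been measured. It differs from compound 1 in one place: 2-fluorophenyl in place of 3-fluorophenyl on a saturated ring carbon. Among the measured compounds shown here, no step between two measured compounds tells how such a change behaves here, so the expectation rests on the pair alone. The author expects the step from compound 1 to compound 3, a 1.2-fold higher number from compound 1 to compound 3 (0.07 log units; within the scatter), to stay within the usual scatter, with no clear direction. Compound 3 is thus estimated at 600 nM in this assay, with a range from 250 nM to 1500 nM.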

Compound 3, half-maximal effective concentration: 1 nM
Estimate against measurement, compound 3: 600-fold (2.78 log units) above; measured number outside the range, below it.
By their numbers in this assay, from the lowest: compound 3; then compounds 1 and 2 (each within the scatter of the next).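

In this assay, among these compounds, the exchange of 3-fluorophenyl for 2-fluorophenyl on a saturated ring carbon gives a 510-fold lower number from compound 1 to compound 3 (2.71 log units; beyond the scatter) and is the first step between two measured compounds that differ in one place. The two groups have the same heavy atoms and the same counts of hydrogen-bond donors and acceptors, so this large step comes from where the fluorine sits on the phenyl ring, which the earlier comparison of compound 1 and compound 2 could not show, since those two differ in more than one place. Nothing in the data accounts for the size of this step, which remains a single observation on a single pair.

The compounds shown leave open whether the gain belongs to fluorine itself or would also appear with a chlorine atom or a methoxy group in its place on the phenyl ring, and how either fluorophenyl compares with a plain phenyl group. They also leave open whether 2-fluorophenyl would give a similar step with an isopropoxy group in place of the methyl group on the anilide.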